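This account rests on a few compounds, and the source may have more. Where it says the series, first, only, none or still open, it means among the compounds named here.

Measured compounds, with their values in a toxicity assay on WI-38 cells (Homo sapiens) for cytotoxicity, read by MTT assay, with a stated time of 48 h; on this read-out higher numbers stand for weaker inhibition and lower numbers for stronger inhibition:
- compound 1 `O=C(/C=C/c1ccc2c(c1)B(O)OC2)c1cccs1`: 26000 nM
- compound 2 `O=C(/C=C/c1ccc2c(c1)B(O)OC2)c1ccc([N+](=O)[O-])cc1`: 39300 nM
- compound 3 `O=C(/C=C/c1ccc2c(c1)B(O)OC2)c1ccc(Cl)c(Cl)c1`: 12500 nM

All three share the same core and differ only in the aryl group on the carbonyl carbon. In this assay compound 1 stands second highest of the three numbers. Its nearest neighbour is compound 2, whose value sits within the usual scatter of repeated measurement, so no order between compound 1 and compound 2 can be read from these two values. Compound 3 lies furthest from compound 1, with a lower number that falls beyond the scatter.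

The next compound to consider is compound 4 `Nc1cccc(C(=O)/C=C/c2ccc3c(c2)B(O)OC3)c1`. Relative to compound 1 the change is 3-aminophenyl in place of thiophen-2-yl on a carbonyl carbon. Within the data shown here, no step between two measured compounds that differ in one place is available, so there is no direct precedent for this exchange. The three measured values all cluster in a narrow band, which argues against a large shift. The step of a 1.0-fold lower number from compound 1 to compound 4 (0.02 log units; within the scatter) is expected to be small, with no clear direction beyond the scatter. For compound 4 the estimate in this assay is 25000 nM, with a range from 10000 nM to 60000 nM.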

Compound 4, half-maximal inhibitory concentration: 25300 nM
Estimate against measurement, compound 4: 1.0-fold (0.01 log units) below, and the stated range covers the measured number.
By their numbers in this assay, from the lowest: compound 3; then compounds 4, 1 and 2 (each within the scatter of the next).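

In this assay, among these compounds, the exchange of thiophen-2-yl for 3-aminophenyl on a carbonyl carbon gives a 1.0-fold lower number from compound 1 to compound 4 (0.01 log units; within the scatter) and so provides the one step at this position that can be read directly. The ring size changes and the entering group carries a hydrogen-bond donor that the leaving group lacks, yet the number does not move beyond the scatter. No measurement offered here bears on a cause for this result.

The compounds shown leave open whether an unsubstituted phenyl group would fall in the same band, so the amine cannot be separated from the ring exchange. Also open, on these data alone, is whether a carboxylic acid on that ring, or a saturated chain in place of the double-bonded chain carbon, would shift the number beyond the scatter.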